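Swapping methyl for chloro on a barely active compound

The compounds below may be only part of what the source reports. "The series", "measured", "known", "first", "only" and "open" are said of these compounds alone.

In a functional assay on MDA-MB-231 cells (Homo sapiens) for antiproliferative activity, read by MTT assay, with a stated time of 24 h (on this read-out lower numbers stand for stronger inhibition and higher numbers for weaker inhibition), compound 3 (`Cc1ccccc1NNC(=O)c1ccccc1NS(=O)(=O)c1cnc(O)nc1O`) reads > 20000 nM, which is a limit of the assay and not a number. Compound 1 (`Cc1cccc(NNC(=O)c2ccc(NS(=O)(=O)c3cnc(O)nc3O)cc2)c1`) reads > 20000 nM, also a limit. Compound 2 (`O=C(NNc1cccc(Cl)c1)c1ccc(NS(=O)(=O)c2cnc(O)nc2O)cc1`) gives a true number, 17400 nM. Compound 3 thus shares (the limit of > 20000 nM in this assay, at which 2 of the 3 values shown sit).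

Compound 4 (`O=C(NNc1ccccc1Cl)c1ccccc1NS(=O)(=O)c1cnc(O)nc1O`) differs from compound 3 by chloro in place of methyl on an aromatic carbon, ortho to a large group. For the measured compounds named here, the one measured step with this swap is an at least 1.1-fold lower number from compound 1 to compound 2 (0.06 log units; that floor lies within the scatter). A step of an at least 1.1-fold lower number from compound 3 to compound 4 (0.04 log units; that floor lies within the scatter) is therefore expected, with no clear change beyond the scatter. Compound 4 is estimated at 18000 nM, with an expected range of 9000 nM to 32000 nM.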

Compound 4, half-maximal inhibitory concentration: 18900 nM
Estimate against measurement, compound 4: 1.1-fold (0.02 log units) below, and the stated range covers the measured number.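

With chloro in place of methyl ortho to a large group, the change gives an at least 1.0-fold lower number from compound 3 to compound 4 (0.02 log units; that floor lies within the scatter). The reading of compound 3 in this assay is a limit and not a number, so this step is only a floor. The swap now appears on a second core, with no change shown beyond the scatter on either: the same change on two cores in this assay, an at least 1.1-fold lower number (0.06 log units; that floor lies within the scatter) from compound 1 to compound 2 and an at least 1.0-fold lower number (0.02 log units; that floor lies within the scatter) from compound 3 to compound 4; the limit leaves it open whether they differ

From the compounds shown here alone, the true size of this step stays open. So does whether an amine or a carboxylic acid in place of the chloro would shift the number in this assay.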